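A longer arm on the amide of compound 1

The source may hold more compounds than are shown below. What is called first, only, known or untested is meant among the compounds shown, and "the series" means these compounds.

Compound 1, `COc1ccc(-c2cnc3nc(N)nc(N4CCN(C(=O)c5ccccc5)CC4)c3n2)cc1OC`, is the reference point. In a functional assay on cells (T-cell, Homo sapiens) for inhibition (a higher number here means a weaker inhibitor, a lower number a stronger inhibitor), compound 1 gives 400 nM, the lowest of the two numbers in hand. Compound 2, `CCOc1nc(N)nc2ncc(-c3ccc(CC)cc3)nc12`, gives 8200 nM in this assay. Compound 3, `CCOc1nc(N)nc2ncc(-c3ccc(C#N)cc3)nc12`, reaches only the limit of > 10000 nM in this assay, so no number is known for it. Within the data shown here, the one measured step, an at least 1.2-fold higher number from compound 2 to compound 3 (0.08 log units; that floor lies within the scatter), concerns a cyano in place of ethyl on an aromatic carbon, a change at a different position and of a different kind from the one examined here, so it offers little guidance. Compound 4, `COc1ccc(-c2cnc3nc(N)nc(N4CCN(C(=O)CCc5ccccc5)CC4)c3n2)cc1OC`, differs from compound 1 at the carbonyl carbon: phenethyl in place of phenyl on a carbonyl carbon. Among the measured compounds shown here, no measured pair shows what lengthening this group does in this assay, so the expectation is a shift no larger than the usual scatter, with the range left wide in either direction. The expected change is a 1.3-fold higher number from compound 1 to compound 4 (0.10 log units; within the scatter). For compound 4 the estimated value in this assay is 500 nM, within a range from 150 nM to 1600 nM.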

Compound 4, half-maximal inhibitory concentration: 100 nM
Beside the measured number, compound 4's estimate is 5.0-fold (0.70 log units) above it; measured number outside the range, below it.
By their numbers in this assay, from the lowest: compound 4; then compound 1; then compound 2. At a limit, above all of these: compound 3.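

On a carbonyl carbon whose other neighbour is an amide-type nitrogen in a ring, phenethyl in place of phenyl gives a 4.0-fold lower number from compound 1 to compound 4 (0.60 log units; beyond the scatter) in this assay, so this position responds to the arm that it carries, and the longer arm is the better of the two. Both groups hold one six-membered aromatic ring of carbon only, with no hydrogen-bond donors or acceptors and no net charge, so they differ here in having 8 heavy atoms rather than 6 and in the ring standing further from the carbonyl. The data shown offer nothing that explains why the longer arm gives the lower number.

A single step cannot show whether the number keeps falling with a longer chain, such as phenylpropyl, or how the shorter benzyl would compare. Also open, on these data alone, is how an amine or a carboxylic acid on the ring of this arm would fare.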